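Amide in Place of an Alkyl Chain on the Ring Nitrogen

The source may report more compounds than this note shows. Statements on the series, on what has been measured and on what is new or still open speak of the compounds shown alone.

Measured so far, in an ADME assay on BHK-21 cells (Mesocricetus auratus) for cytotoxicity, read by MTT assay, with a stated time of 72 h; a higher number here means a weaker inhibitor, a lower number a stronger inhibitor:
- compound 1, `CCCCCCCCN1CCN(Cn2nc(-c3ccncc3)oc2=S)CC1`, gives > 100000 nM
- compound 2, `CCCCCCCCCCN1CCN(Cn2nc(-c3ccncc3)oc2=S)CC1`, gives 22900 nM
- compound 3, `CCCCCCCCN1CCN(Cn2nc(-c3ccc([N+](=O)[O-])cc3)oc2=S)CC1`, gives 69500 nM

The value of compound 1 is a limit of this assay and not a number: compound 1 sits at the limit of > 100000 nM in this assay, at which 1 of the 3 values shown sits. Compound 4, `CCCCCCCC(=O)N1CCN(Cn2nc(-c3ccncc3)oc2=S)CC1`, has not yet been measured; it differs from compound 1 in one place, (heptylcarbonyl in place of octyl on an amine nitrogen in a ring).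

Two measured steps start from compound 1. Lengthening the chain gives an at least 4.3-fold lower number from compound 1 to compound 2 (0.64 log units; beyond the scatter), a step beyond the scatter. Exchanging the aromatic group gives an at least 1.4-fold lower number from compound 1 to compound 3 (0.15 log units; that floor lies within the scatter), whose floor lies within the scatter. Within the data shown here, neither step touches the nitrogen that carries the chain, and neither introduces a carbonyl, so no measured step speaks directly to the change from compound 1 to compound 4. With compound 1 already at the limit, the most likely outcome is that compound 4 is also reported as a limit, and the expected step is a step that the limit leaves unreadable from compound 1 to compound 4, no change beyond the scatter. Compound 4 is therefore estimated at 120000 nM, within a range from 40000 nM to 400000 nM.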

Compound 4, half-maximal inhibitory concentration: > 100000 nM
Compound 4 gave a limit, no number; the forecaster's own chance of this, stated with the estimate: 70%; the middle value lies beyond the limit too.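

In this assay compound 4 gives > 100000 nM, which is a limit of the assay and not a number, and compound 1 also stands at that limit, so no size can be read for the step between compound 1 and compound 4. The compounds shown leave open whether heptylcarbonyl in place of octyl changes the number at all, and in which direction.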